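Working notes on cytotoxicity: estimating compound 4

The compounds below may be only part of what the source reports. "The series", "measured", "known", "first", "only" and "open" are said of these compounds alone.

Measured so far:
- Compound 1 `CC(C)CSc1nc(N)nc2c1ncn2/C=C1/CC1(CO)CO` gives 60000 nM in an ADME assay on CCRF-HSB-2 cells (Homo sapiens) for cytotoxicity, with a stated time of 7 days; on this read-out higher numbers stand for lower toxicity in this test and lower numbers for higher toxicity in this test.
- Compound 2 `Nc1nc(NCc2ccccc2)c2ncn(/C=C3/CC3(CO)CO)c2n1` gives > 20000 nM in this assay, which is a limit of the assay.
- Compound 3 `Nc1nc(N2CCCC2)c2ncn(/C=C3/CC3(CO)CO)c2n1` gives > 20000 nM in this assay, again a limit.

For the measured compounds named here, compound 1 stands as the only compound of the three with an actual number; the other two values are limits, as noted in the limit of > 20000 nM in this assay, at which 2 of the 3 values shown sit. Because of the limit of > 20000 nM in this assay, at which 2 of the 3 values shown sit, the steps a step that the limit leaves unreadable from compound 1 to compound 2 and a step that the limit leaves unreadable from compound 1 to compound 3 cannot be sized, and a step that the two limits leave unreadable from compound 2 to compound 3 is equally unreadable. All three compounds sit at the weakly toxic end of this assay.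

Compound 4 `CCCCCCOc1nc(N)nc2c1ncn2/C=C1/CC1(CO)CO` differs from compound 1 by hexyloxy in place of isobutylsulfanyl on an aromatic carbon. Going by the values given here, none of the measured steps covers this kind of exchange with a readable size, so no direction can be taken from them. Compound 4 is therefore expected to stay close to compound 1, with a 1.2-fold lower number from compound 1 to compound 4 (0.08 log units; within the scatter) expected to lie within the scatter. The estimate for compound 4 is 50000 nM, with a range from 15000 nM to 150000 nM. A reported limit rather than a number is considered plausible for compound 4.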

Compound 4, half-maximal cytotoxic concentration: > 20000 nM
Compound 4: only a limit was reported; the forecaster's own chance of this, stated with the estimate: 45%; the middle value lies beyond the limit too.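

Compound 4 gives > 20000 nM in this assay, which is a limit of the assay. No new step linking compound 4 with compound 1, compound 2 or compound 3 can be read: the limit of > 20000 nM in this assay, at which 3 of the 4 values shown sit.

As far as these compounds go, whether hexyloxy in place of isobutylsulfanyl shifts the value in either direction stays open, as does any order among compound 2, compound 3 and compound 4.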